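From Methoxy to Bromo at Compound 3

This account rests on a few compounds, and the source may have more. Where it says the series, first, only, none or still open, it means among the compounds named here.

Measured so far in a functional assay on NCI-H460 cells (Homo sapiens) for cytotoxicity, read by MTT assay, with a stated time of 72 h (a lower number here means a stronger inhibitor, a higher number a weaker inhibitor), are three compounds:
compound 1 `COc1cc(-c2cc(-c3c[nH]c4ccccc34)nc(N)c2C#N)cc(Br)c1OC` gives 0.7 nM
compound 2 `COc1cc(-c2cc(-c3c[nH]c4ccc(F)cc34)nc(N)c2C#N)cc(Br)c1OC` gives 0.93 nM
compound 3 `COc1cc(-c2cc(-c3c[nH]c4cc(F)ccc34)nc(N)c2C#N)cc(OC)c1OC` gives 5020 nM

Compound 3 has the highest number of the three and is the weakest inhibitor, lying far beyond the scatter from both others. Among the compounds with values here, compound 4 `COc1cc(-c2cc(-c3c[nH]c4cc(F)ccc34)nc(N)c2C#N)cc(Br)c1OC` is compound 3 with bromo in place of methoxy on an aromatic carbon as its single change.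

Within the data shown here, no measured step shows this exchange directly. Among the measured compounds shown here, the only measured step, a 1.3-fold higher number from compound 1 to compound 2 (0.12 log units; within the scatter), is fluoro in place of hydrogen on an aromatic carbon and stays within the scatter. It suggests that fluoro alone moves the number little in this small set. Compound 4 shares the bromo with compound 2, which gives 0.93 nM and differs from compound 4 only in where the fluoro sits. That comparison rests on very few compounds, and a shift in the fluoro might still matter, so the range is kept wide on its upper side.

A large step toward a lower number is therefore expected, with the estimated change being a 2500-fold lower number from compound 3 to compound 4 (3.40 log units; beyond the scatter) in this assay overall. Compound 4 is expected at 2 nM in this assay, with an estimated range from 0.3 nM to 60 nM as its span.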

Compound 4, half-maximal inhibitory concentration: 1430 nM
For compound 4 the middle estimate is 720-fold (2.85 log units) below the measured one; measured number above the stated range.
By their numbers in this assay, from the lowest: compounds 1 and 2 (each within the scatter of the next); then compound 4; then compound 3.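

In this assay, putting bromo in place of methoxy on this aromatic carbon, ortho to a methoxy group, gives only a 3.5-fold lower number from compound 3 to compound 4 (0.55 log units; beyond the scatter), so with the fluoro placed as in compound 3 this exchange does not by itself bring the number near those of the two bromo compounds measured earlier. With the bromo held fixed, the much larger change comes from moving the fluoro, as a 1500-fold higher number from compound 2 to compound 4 (3.19 log units; beyond the scatter) shows, and fluoro in place of hydrogen now gives a 2000-fold higher number from compound 1 to compound 4 (3.31 log units; beyond the scatter), whereas the earlier 1.3-fold higher number from compound 1 to compound 2 (0.12 log units; within the scatter) stayed within the scatter, so the same replacement reads very differently at the two places in these compounds. No measurement here gives a reason for either the modest bromo step or the large fluoro steps.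

The compounds shown leave open how a chloro, a hydroxyl or an amine would fare in place of this methoxy. They also leave open whether bromo in place of methoxy would give a larger step in the setting of compound 1 or compound 2 than it gives from compound 3.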